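The source may report more compounds than this note shows. Statements on the series, on what has been measured and on what is new or still open speak of the compounds shown alone.

Measured so far in a physicochemical assay for solubility, read by spectrophotometry, in phosphate buffer, with a stated time of 2 h, at pH 7.4; on this read-out higher numbers stand for higher solubility and lower numbers for lower solubility:
- compound 1 `COc1ccc2[nH]c(C(=O)N3CC(=O)N(Cc4ccccc4)[C@@H](CN4CCC5(CC4)CC5)C3)cc2c1`: 28200 nM
- compound 2 `COc1ccc2[nH]c(C(=O)N3CC(=O)N(Cc4ccccc4)[C@@H](CN4C(=O)c5ccccc5C4=O)C3)cc2c1`: a limit only, > 100000 nM
- compound 3 `COc1ccc2[nH]c(C(=O)N3CC(=O)N(Cc4ccccc4)[C@@H](CN4CCC(C(C)C)CC4)C3)cc2c1`: 12000 nM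

Compound 3 stands lowest of the two numbers in this assay; its nearest neighbour is compound 1, with a 2.4-fold lower number from compound 1 to compound 3 (0.37 log units; beyond the scatter). Compound 2 sits at the limit of > 100000 nM in this assay, at which 1 of the 3 values shown sits, so only a limit is known for it. The step to compound 4 `COc1ccc2[nH]c(C(=O)N3CC(=O)N(Cc4ccccc4)[C@@H](CN4CCc5ccccc5C4)C3)cc2c1` is 1,2,3,4-tetrahydroisoquinolin-2-yl in place of 4-isopropylpiperidin-1-yl on a saturated chain carbon bound to a saturated ring carbon. The measured steps that touch the same place are a 2.4-fold lower number from compound 1 to compound 3 (0.37 log units; beyond the scatter), an at least 3.5-fold higher number from compound 1 to compound 2 (0.54 log units; beyond the scatter) and an at least 8.3-fold lower number from compound 2 to compound 3 (0.92 log units; beyond the scatter); the last two rest on the limit of compound 2 and give only a floor. The group entering in compound 4 carries a six-membered aromatic ring, as did the group of compound 2, but none of its carbonyls, while the saturated ring with one nitrogen is kept, as in compound 1 and compound 3. Compound 4 is therefore expected to move upward from compound 3 by a 1.8-fold higher number from compound 3 to compound 4 (0.26 log units; within the scatter), a step near the edge of the scatter. Compound 4 is estimated at 22000 nM, with a range from 7000 nM to 70000 nM.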

Compound 4, solubility: 9000 nM
Compound 4: middle estimate off by 2.4-fold (0.39 log units), on the high side; the measured number falls inside the stated range.
By their numbers in this assay, from the lowest: compounds 4 and 3 (each within the scatter of the next); then compound 1. At a limit, above all of these: compound 2.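

In this assay, 1,2,3,4-tetrahydroisoquinolin-2-yl in place of 4-isopropylpiperidin-1-yl gives a 1.3-fold lower number from compound 3 to compound 4 (0.12 log units; within the scatter), so the entering six-membered aromatic ring does not separate these two compounds on this saturated chain carbon. The group of compound 1 remains distinct from this new group, with a 3.1-fold lower number from compound 1 to compound 4 (0.50 log units; beyond the scatter). The step of an at least 11-fold lower number from compound 2 to compound 4 (1.04 log units; beyond the scatter) rests on a limit and gives only a floor, and a six-membered aromatic ring in both groups does not bring these two compounds together; the limit reads: the limit of > 100000 nM in this assay, at which 1 of the 4 values shown sits.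

Whether the two carbonyls set compound 2 apart stays open, since only one group carrying them is shown. Also open, going by these compounds, is how this assay would read with a carboxylic acid, a morpholine or an open-chain benzylamine at this position.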